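Removing a Ring Hydroxy: Expecting the Next Measurement

The source may report more compounds than this note shows. Statements on the series, on what has been measured and on what is new or still open speak of the compounds shown alone.

Measured compounds:
compound 1 `N=C(N)NCCC[C@H](N)C(=O)NS(=O)(=O)OC[C@H]1OC[C@@H](n2cnc3c(N)ncnc32)C[C@@H]1O`: 600 nM
compound 2 `Nc1ncnc2c1ncn2[C@@H]1CO[C@H](COS(=O)(=O)NC(=O)[C@@H]2CCCN2)[C@@H](O)C1`: 2800 nM
compound 3 `C[C@H](N)C(=O)NS(=O)(=O)OC[C@H]1OC[C@@H](n2cnc3c(N)ncnc32)[C@H](O)[C@@H]1O`: 300 nM

Of the compounds shown here, three have been measured in a functional assay on PBMC cells (Homo sapiens) for inhibition; a higher number here means a weaker inhibitor, a lower number a stronger inhibitor. Compound 3 gives 300 nM, and compound 1, with 600 nM, lies within the scatter of it; compound 2, with 2800 nM, stands beyond the scatter above both. Compound 4 `C[C@H](N)C(=O)NS(=O)(=O)OC[C@H]1OC[C@@H](n2cnc3c(N)ncnc32)C[C@@H]1O` differs from compound 3 in one place: hydrogen in place of hydroxy on a saturated ring carbon. Among the measured compounds shown here, the only measured step, a 4.7-fold higher number from compound 1 to compound 2 (0.67 log units; beyond the scatter), concerns the group on the carbonyl carbon and not the ring, so it does not bear on this change. For the measured compounds named here, compound 1 and compound 3 differ at the ring hydroxy and elsewhere, and their two values lie within the scatter of each other, which is the only hint the numbers give. Going by the values given here, with no step that bears directly on it, the expected step for compound 4 is a 1.7-fold higher number from compound 3 to compound 4 (0.22 log units; within the scatter), a small one that may stay within the scatter. Compound 4 is therefore estimated at 500 nM, with a range from 200 nM to 1500 nM.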

Compound 4, half-maximal inhibitory concentration: 5500 nM
Estimate against measurement, compound 4: 11-fold (1.04 log units) below; measured number above the stated range.
By their numbers in this assay, from the lowest: compounds 3 and 1 (each within the scatter of the next); then compounds 2 and 4 (each within the scatter of the next).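

In this assay, the hydroxy on this saturated ring carbon proves to matter greatly when 1-aminoethyl sits on the carbonyl carbon: hydrogen in its place gives an 18-fold higher number from compound 3 to compound 4 (1.26 log units; beyond the scatter). Among the compounds without this hydroxy, the group on the carbonyl carbon has uneven weight: 1-aminoethyl in place of pyrrolidin-2-yl gives a 2.0-fold higher number from compound 2 to compound 4 (0.29 log units; within the scatter), whereas a hydrogen atom in place of the chain group of compound 1 gives a 9.2-fold higher number from compound 1 to compound 4 (0.96 log units; beyond the scatter). The loss seen on removing the hydroxy therefore belongs to this pairing, and the ring without the hydroxy can still reach a far lower number with the chain group of compound 1.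

On these data alone, whether a methoxy group or a fluorine atom on this ring carbon would keep the number near that of compound 3 stays open. The compounds shown offer no measured explanation for any of these steps.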